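The source may hold more compounds than are shown below. What is called first, only, known or untested is meant among the compounds shown, and "the series" means these compounds.

Compound 3 `COc1cc(-c2nn(-c3cccc(NC(=O)Nc4ccc(Cl)c(C(F)(F)F)c4)c3)cc2-c2ccncc2)ccc1Cl` carries the shared core with a urea whose carbonyl carbon bears (4-chloro-3-(trifluoromethyl)phenyl)amino. In a functional assay on TK-10 cells (Homo sapiens) for inhibition, read by sulforhodamine B assay, with a stated time of 48 h (on this read-out lower numbers stand for higher toxicity in this test and higher numbers for lower toxicity in this test), compound 3 gives only the limit > 32500 nM, so no number is known for it. Compound 1 `COc1cc(-c2nn(-c3cccc(NC(=O)Nc4ccc(Cl)c(Cl)c4)c3)cc2-c2ccncc2)ccc1Cl` likewise gives only a limit, > 50000 nM, in this assay. Compound 2 `COc1cc(-c2nn(-c3cccc(NC(=O)c4ccc(Cl)c(C(F)(F)F)c4)c3)cc2-c2ccncc2)ccc1Cl`, the benzamide counterpart, also gives only a limit, > 32500 nM. The steps a step that the two limits leave unreadable from compound 1 to compound 2, a step that the two limits leave unreadable from compound 1 to compound 3 and a step that the two limits leave unreadable from compound 2 to compound 3 therefore carry no readable size, because the limit of > 32500 nM in this assay, at which 2 of the 3 values shown sit, and the limit of > 50000 nM in this assay, at which 1 of the 3 values shown sits, cap every value in the set.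

Compound 4 `COc1cc(-c2nn(-c3cccc(NC(=O)c4ccccc4)c3)cc2-c2ccncc2)ccc1Cl` differs from compound 3 by phenyl in place of (4-chloro-3-(trifluoromethyl)phenyl)amino on a carbonyl carbon. Two of the measured steps bear on it: the swap of the urea nitrogen for a direct aryl on the carbonyl carbon, covered by the step from compound 2 to compound 3, and the exchange of aryl substituents, covered by the step from compound 1 to compound 3; both are unreadable, so no direction or size of step in this assay can be taken from them. The only usable point is that the three measured compounds all sit at a limit, which gives no reason to expect compound 4 to move beyond the scatter.

The value for compound 4 in this assay is therefore expected near 40000 nM, within 10000 nM to 100000 nM, most likely again reported as a limit. The step that this estimate implies from compound 3 to compound 4 is a step that the limit leaves unreadable from compound 3 to compound 4, expected to be nil within scatter.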

Compound 4, concentration lethal to 50% of the cells: > 100000 nM
Compound 4 gave a limit, no number; the forecaster's own chance of this, stated with the estimate: 75%; middle value at least 2.5-fold (0.39 log units) away from the limit.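

Compound 4, like compound 1, compound 2 and compound 3, gives only a limit in this assay, so none of the steps from those three compounds to compound 4 can be read. The compounds shown leave open whether any change of the group on the carbonyl carbon shifts the read-out at all: none of them has a numeric value.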